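The compounds below may be only part of what the source reports. "The series", "measured", "known", "first", "only" and "open" are said of these compounds alone.

Compound 1 `Cc1nccn1-c1csc(Nc2cccc(Br)c2)n1`: > 100000 nM
Compound 2 `COc1ccc(Nc2nc(-n3cnc4ccccc43)cs2)cc1`: > 100000 nM
Compound 3 `COc1ccc(Nc2nc(-n3ccnc3C)cs2)cc1`: 1600 nM

In a functional assay on RKO cells (Homo sapiens) for cytotoxicity, read by resazurin assay, with a stated time of 72 h (a lower number here means a stronger inhibitor, a higher number a weaker inhibitor), compound 1 gives only a limit, > 100000 nM, and no number. Compound 2 likewise sits at a limit, > 100000 nM. Compound 3 gives a real number, 1600 nM. Compound 1 thus stands at the weak end of what is shown, at the limit of > 100000 nM in this assay, at which 2 of the 3 values shown sit. Compound 4 `COc1cccc(Nc2nc(-n3ccnc3C)cs2)c1` arises from compound 1 by one change: methoxy in place of bromo on an aromatic carbon. Among the measured compounds shown here, no measured pair shows this change directly. Compound 3 carries the same methoxy group on the same core and gives 1600 nM, which hints that the change could bring measurable potency. The step from compound 1 to compound 4 is expected to be an at least 10-fold lower number from compound 1 to compound 4 (1.00 log units; beyond the scatter), toward stronger inhibition. Compound 4 is estimated at 10000 nM, with a range of 1500 nM to 100000 nM.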

Compound 4, half-maximal inhibitory concentration: 22500 nM
Compound 4: the middle estimate sits 2.3-fold (0.35 log units) below what was measured, and the stated range covers the measured number.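

In this assay, methoxy in place of bromo on this aromatic carbon gives the first measurable number among these meta-substituted compounds, an at least 4.4-fold lower number from compound 1 to compound 4 (0.64 log units; beyond the scatter). From the compounds shown here alone, the true size of this step stays unknown because compound 1 gives only a limit: the limit of > 100000 nM in this assay, at which 2 of the 4 values shown sit. Compound 4 gives 22500 nM, while compound 3, with its methoxy at another carbon of the same ring, gives the lower number of 1600 nM, so the place of the methoxy appears to matter in this pair. Going by these compounds, whether an amine or a longer ethoxy chain at this carbon would lower the number further remains open.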